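The compounds below may be only part of what the source reports. "The series", "measured", "known", "first", "only" and "open" are said of these compounds alone.

Measured set:
compound 1 `Cc1ccc2[nH]c(=O)c(-c3nc4cc([N+](=O)[O-])ccc4[nH]3)cc2c1` — in a functional assay on HepG2 cells (Homo sapiens) for cytotoxicity, read by MTT assay, with a stated time of 48 h (a lower number here means a stronger inhibitor, a higher number a weaker inhibitor), compound 1 gives > 100000 nM, which is a limit of the assay.
compound 2 `O=c1[nH]c2ccccc2cc1-c1nc2cc([N+](=O)[O-])ccc2[nH]1` — in this assay compound 2 gives > 100000 nM, again a limit.
compound 3 `COc1ccc2[nH]c(=O)c(-c3nc4cc(Cl)ccc4[nH]3)cc2c1` — in this assay compound 3 gives > 100000 nM, again a limit.

Compound 1 stands only at a limit in this assay. Compound 2 and compound 3 likewise reach only limits, so no order among the three can be read. The change from compound 1 to compound 4 `Cc1ccc2[nH]c(=O)c(-c3nc4ccccc4[nH]3)cc2c1` is hydrogen in place of nitro on an aromatic carbon. For the measured compounds named here, the one measured step, a step that the two limits leave unreadable from compound 1 to compound 2, is left unreadable by its two limits, and the evidence the limit of > 100000 nM in this assay, at which 3 of the 3 values shown sit, places every value at the same limit. No size or direction can therefore be drawn for the step to compound 4; the expectation is that it too reaches no number, the estimated step that the limit leaves unreadable from compound 1 to compound 4 meaning none beyond the scatter. Compound 4 is expected at 200000 nM, within 50000 nM to 800000 nM.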

Compound 4, half-maximal inhibitory concentration: > 100000 nM
Compound 4 ended at the assay's limit; the forecaster's own chance of this, stated with the estimate: 85%; the middle value is on the limit's open side.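

No step can be read from compound 1 to compound 4, as both stand only at a limit: the limit of > 100000 nM in this assay, at which 4 of the 4 values shown sit.

The compounds shown leave open whether any change to the shared core gives a readable value in this assay.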